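This account rests on a few compounds, and the source may have more. Where it says the series, first, only, none or still open, it means among the compounds named here.

Working notes on the series, read in an ADME assay on MIA PaCa-2 cells (Homo sapiens) for cytotoxicity, read by MTT assay, with a stated time of 72 h; on this read-out higher numbers stand for weaker inhibition and lower numbers for stronger inhibition.

Compound 1 `COc1ccc(C2=C(c3cc(OC)c(OC)c(OC)c3)C(=O)C(O)C2)cc1` carries a free hydroxyl on the saturated ring carbon. In this assay compound 1 returns only a limit, < 1 ug/mL. Compound 3 `COc1ccc(C2=C(c3cc(OC)c(OC)c(OC)c3)C(=O)C(O[SiH2]C(C)(C)C)C2)cc1` is the corresponding silyl ether. In this assay compound 3 likewise returns a limit, < 1 ug/mL. The change from compound 3 to compound 1 is a hydrogen atom in place of a group of 5 heavy atoms (4 carbon, 1 silicon; no ring), on an oxygen on a saturated carbon and its size is a step that the two limits leave unreadable from compound 3 to compound 1: both compounds sit at the limit of < 1 ug/mL in this assay, at which 2 of the 3 values shown sit, so no number can be attached to the step.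

Compound 2 `COc1ccc(OC)c(C2=C(c3cc(OC)c(OC)c(OC)c3)C(=O)CC2O[SiH2]C(C)(C)C)c1` has a core that differs from the core of compound 3 in more than one place; that difference is not broken down here. In this assay compound 2 gives a limit, > 100 ug/mL, which is the limit of > 100 ug/mL in this assay, at which 1 of the 3 values shown sits.

Compound 4 `COc1ccc(OC)c(C2=C(c3cc(OC)c(OC)c(OC)c3)C(=O)CC2O)c1` is the open hydroxyl analogue of compound 2 and has not been measured. Compound 4 differs from compound 2 by a hydrogen atom in place of a group of 5 heavy atoms (4 carbon, 1 silicon; no ring), on an oxygen on a saturated carbon, the same kind of change as from compound 3 to compound 1, and the place is described in the same words for both pairs. Within the data shown here, the size of that change is not readable from compound 3 and compound 1, whose values are both limits, and no other measured pair shows it. Compound 4 is therefore expected to move by about an at least 3.3-fold lower number from compound 2 to compound 4 (0.52 log units; beyond the scatter) in this assay, with wide uncertainty in either direction. The estimated value for compound 4 in this assay is 30 ug/mL, expected to fall between 3 ug/mL and 150 ug/mL.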

Compound 4, half-maximal inhibitory concentration: > 100 ug/mL
Compound 4: no number, only a limit (the forecaster's own chance of this, stated with the estimate: 40%); middle value at least 3.3-fold (0.52 log units) away from the limit.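

Compound 4 and compound 2 both sit at the same limit in this assay, so no step can be read between them: the limit of > 100 ug/mL in this assay, at which 2 of the 4 values shown sit.

The compounds shown leave open how large the change to a hydrogen atom in place of the group of 5 heavy atoms is in either pair, compound 3 with compound 1 or compound 2 with compound 4.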